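Trifluoromethyl in place of methyl on a carbonyl carbon

This account rests on a few compounds, and the source may have more. Where it says the series, first, only, none or still open, it means among the compounds named here.

Compound 1 `CCCCCCCC[C@@]1(C)SC(O)=CC1=O`: 17.6 ug/mL
Compound 2 `CCCCCCCC[C@@]1(C)SC(O)=C(C)C1=O`: 48 ug/mL
Compound 3 `CCCCCCCC[C@@]1(C)SC(O)=C(C(C)=O)C1=O`: 12.5 ug/mL

These values come from a functional assay on MCF7 cells (Homo sapiens) for inhibition, read by radiometric assay and XTT assay (a lower number here means a stronger inhibitor, a higher number a weaker inhibitor), and the three compounds differ only in what sits on a double-bonded ring carbon. Two steps place compound 3. One is a 1.4-fold lower number from compound 1 to compound 3 (0.15 log units; within the scatter) and marks no real difference, while the other is a 3.8-fold lower number from compound 2 to compound 3 (0.58 log units; beyond the scatter) and is modest.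

Compound 4 `CCCCCCCC[C@@]1(C)SC(O)=C(C(=O)C(F)(F)F)C1=O` differs from compound 3 by trifluoromethyl in place of methyl on a carbonyl carbon and in nothing else. Among the compounds with values here, no measured step makes this swap, so the evidence is indirect. The remaining step on that ring carbon is a 2.7-fold higher number from compound 1 to compound 2 (0.44 log units; beyond the scatter) and is also modest. Even the full exchange of hydrogen for acetyl that gives compound 3 stayed within the scatter, and the swap in compound 4 leaves that acetyl's carbonyl in place. In this assay a small change is therefore expected, with no direction favoured and nothing beyond the scatter. The expected move is a 1.0-fold lower number from compound 3 to compound 4 (0.02 log units; within the scatter) and would leave the two compounds practically level. For compound 4 the estimated value is 12 ug/mL with an expected range from 5 ug/mL to 30 ug/mL in this assay.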

Compound 4, half-maximal inhibitory concentration: 18.4 ug/mL
For compound 4 the middle estimate is 1.5-fold (0.19 log units) below the measured one; the measured number falls inside the stated range.
By their numbers in this assay, from the lowest: compounds 3, 1 and 4 (each within the scatter of the next); then compound 2.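

In this assay, within the data shown here, the swap gives a 1.5-fold higher number from compound 3 to compound 4 (0.17 log units; within the scatter) and so, on this carbonyl carbon, trifluoromethyl and methyl cannot be told apart, which the earlier compounds could not show because all their changes lay on the double-bonded ring carbon. With a 1.0-fold higher number from compound 1 to compound 4 (0.02 log units; within the scatter) the (trifluoromethyl)carbonyl group stays level with plain hydrogen on that ring carbon, and with a 2.6-fold lower number from compound 2 to compound 4 (0.42 log units; beyond the scatter) it stays clearly apart from methyl there, so among these four compounds only compound 2 stands out, as the weakest inhibitor. No measurement here accounts for these numbers or says why methyl on the ring carbon alone stands apart.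

Among these compounds, whether a phenyl ring or a longer chain on the carbonyl carbon would also leave the number level remains open, since trifluoromethyl and methyl are the only two groups compared at that place. Going by these compounds, it is equally open whether an amine or a carboxylic acid on the double-bonded ring carbon would stay level with hydrogen, as both carbonyl groups do, or would stand apart, as methyl does.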